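Shifting a Methoxy Group on the Benzyl Ring

The compounds below may be only part of what the source reports. "The series", "measured", "known", "first", "only" and "open" are said of these compounds alone.

Measured compounds:
- Compound 1, `O=C(NC1CCN(Cc2ccc(Br)cc2)CC1)c1cccc2ccccc12`: 44 nM
- Compound 2, `O=C(NC1CCN(Cc2cccc(C(F)(F)F)c2)CC1)c1cccc2ccccc12`: 119 nM
- Compound 3, `COc1cccc(CN2CCC(NC(=O)c3cccc4ccccc34)CC2)c1`: 168 nM

All three share one core and differ only in the group carried on the saturated chain carbon bound to an amine nitrogen in a ring. In an assay on isolated protein for displacement of a labelled ligand from D(4) dopamine receptor (Homo sapiens) (a higher number here means a weaker inhibitor, a lower number a stronger inhibitor), compound 3 gives the highest of the three numbers. Its nearest neighbour is compound 2, and that gap is within the scatter a 1.4-fold higher number from compound 2 to compound 3 (0.15 log units; within the scatter). The furthest is compound 1, and that gap is beyond the scatter a 3.8-fold higher number from compound 1 to compound 3 (0.58 log units; beyond the scatter).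

Compound 4, `COc1ccc(CN2CCC(NC(=O)c3cccc4ccccc34)CC2)cc1`, has not yet been measured. It differs from compound 3 in one place: 4-methoxyphenyl in place of 3-methoxyphenyl on a saturated chain carbon bound to an amine nitrogen in a ring.

Two measured steps change the group at this place: a 2.7-fold higher number from compound 1 to compound 2 (0.43 log units; beyond the scatter) and a 3.8-fold higher number from compound 1 to compound 3 (0.58 log units; beyond the scatter). Each swaps one substituent for another; neither moves the same substituent to a different position on the ring, so none of them bears directly on this change. With no guidance of that kind, the expectation for compound 4 in this assay is a step of no more than the usual scatter, a 1.1-fold lower number from compound 3 to compound 4 (0.05 log units; within the scatter). Compound 4 is therefore estimated at 150 nM, with a range from 50 nM to 450 nM.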

Compound 4, inhibition constant: 223 nM
For compound 4 the middle estimate is 1.5-fold (0.17 log units) below the measured one; the range from low to high includes it.
By their numbers in this assay, from the lowest: compound 1; then compounds 2, 3 and 4 (each within the scatter of the next).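

In this assay, within the data shown here, moving the methoxy group gives a 1.3-fold higher number from compound 3 to compound 4 (0.12 log units; within the scatter), so 3-methoxyphenyl and 4-methoxyphenyl cannot be told apart here, which is the first direct reading of a positional change at this place. Compound 4 also stays within the scatter of the trifluoromethyl compound, with a 1.9-fold higher number from compound 2 to compound 4 (0.27 log units; within the scatter), whereas methoxy in place of bromo gives a 5.1-fold higher number from compound 1 to compound 4 (0.70 log units; beyond the scatter), so among these compounds only compound 1 stands clearly apart from compound 4. Nothing shown explains this separation.

The compounds shown leave open whether moving the bromo group on the ring, as the methoxy group was moved here, would also leave the number unchanged. They also leave open whether a chloro group, an amine or a carboxylic acid at this place would fall near compound 1 or near compound 4.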